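A dichlorophenyl swap on the shared core

The source may hold more compounds than are shown below. What is called first, only, known or untested is meant among the compounds shown, and "the series" means these compounds.

Three related compounds have so far been examined in a functional assay on HepG2 cells (Homo sapiens) for cytotoxicity, read by MTT assay, with a stated time of 72 h (a higher number here means a weaker inhibitor, a lower number a stronger inhibitor), and their results differ in kind. Compound 1 `CNC(=O)c1cc(Oc2ccc(C3=NNC(c4ccc(Cl)cc4Cl)C3)cc2)ccn1` has the entry "not determined" (no result reported) and so offers no result. Compound 2 `CNC(=O)c1cc(Oc2ccc(C3=NNC(c4ccc([N+](=O)[O-])cc4)C3)cc2)ccn1` gives > 50000 nM as a limit of the assay and not a number. For the measured compounds named here, compound 3 `CNC(=O)c1cc(Oc2ccc(C3=NNC(c4ccc(OC)cc4)C3)cc2)ccn1` gives 9640 nM as the only exact number available.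

Compound 4 `CNC(=O)c1cc(Oc2ccc(C3=NNC(c4ccc(Cl)c(Cl)c4)C3)cc2)ccn1` departs from compound 3 in one place. The change is 3,4-dichlorophenyl in place of 4-methoxyphenyl on a saturated ring carbon and it sits on a saturated ring carbon. Going by the values given here, the one measured step that bears on it is an at least 5.1-fold lower number from compound 2 to compound 3 (0.71 log units; beyond the scatter) with methoxy in place of nitro on an aromatic carbon. That step shows that a swap on this aromatic ring can move the number well beyond the scatter, but it involves no chlorine and gives only a loose guide. The expected change is a 1.2-fold higher number from compound 3 to compound 4 (0.10 log units; within the scatter) and so a small rise, probably within the scatter. Compound 4 is estimated at 12000 nM with an expected range from 4000 nM to 40000 nM in this test.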

Compound 4, half-maximal inhibitory concentration: 14400 nM
Beside the measured number, compound 4's estimate is 1.2-fold (0.08 log units) below it; low and high end bracket the measured number.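

In this assay, this saturated ring carbon now has a chlorine-bearing aromatic ring with a numerical result, and the swap gives a 1.5-fold higher number from compound 3 to compound 4 (0.17 log units; within the scatter). Thus, 3,4-dichlorophenyl and 4-methoxyphenyl are not told apart here, even though the two rings carry different substituents. The comparison with the nitro compound gives an at least 3.4-fold lower number from compound 2 to compound 4 (0.54 log units; beyond the scatter), so 4-nitrophenyl now stands apart from two different replacements, not just one, although compound 2's entry is a limit of the assay and not a number: the limit of > 50000 nM in this assay, at which 1 of the 4 values shown sits.

From the compounds shown here alone, it remains open whether an amine or a carboxylic acid on this aromatic ring, or a longer chain in place of the ring, would move the number. Also open, going by these compounds, is whether a phenyl ring with a single chlorine would differ from 3,4-dichlorophenyl.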